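A few compounds are considered here, and "the series" means these few. Any claim that something is new, unique, unknown or untested is made for them only; others in the source may bear on it.

Measured compounds:
compound 1, `CC(C)[C@H](NC(=O)COc1cccc2ccccc12)C(=O)N[C@@H](CC(=O)O)C(=O)CSc1nc(-c2ccccc2)no1`, 102000 nM in a functional assay on Jurkat cells (Homo sapiens) for inhibition; on this read-out lower numbers stand for stronger inhibition and higher numbers for weaker inhibition
compound 2, `CC(C)[C@H](NC(=O)COc1cccc2ccccc12)C(=O)N[C@@H](CC(=O)O)C(=O)CSc1nncn1C`, > 200000 nM in this assay

Compound 2 stands at the weaker end of the two numbers shown. In this assay compound 2 gives only a limit, > 200000 nM, not a number. In this assay compound 1 gives 102000 nM. Among the measured compounds shown here, the one measured step, an at least 1.9-fold higher number from compound 1 to compound 2 (0.29 log units; that floor lies within the scatter), rests on that limit, (the limit of > 200000 nM in this assay, at which 1 of the 2 values shown sits), so its true size is unknown.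

Compound 3, `CC(C)[C@H](NC(=O)COc1cccc2ccccc12)C(=O)N[C@@H](CC(=O)O)C(=O)COc1nc2ccccc2[nH]1`, has not yet been measured. It differs from compound 2 in one place: (1H-benzimidazol-2-yl)oxy in place of (4-methyl-4H-1,2,4-triazol-3-yl)sulfanyl on a saturated chain carbon bound to a carbonyl carbon. For the measured compounds named here, this change removes the sulfur link and the triazole together and brings in an oxygen link and a benzimidazole, so the only measured step, which swapped one sulfur-bound heterocycle for another, bears on it just loosely. With compound 2 fixed only as a limit, the expected step of an at least 2.0-fold lower number from compound 2 to compound 3 (0.30 log units; that floor lies within the scatter) is itself an estimate of return to a numbered value. Compound 3 is therefore expected to fall near 100000 nM, with a range from 15000 nM to 300000 nM.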

Compound 3, half-maximal inhibitory concentration: > 200000 nM
Compound 3: a limit, no number; the forecaster's own chance of this, stated with the estimate: 35%; middle value at least 2.0-fold (0.30 log units) from the limit.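

In this assay compound 3 gives > 200000 nM, which is a limit and not a number. Set against the only numbered compound, the reading is an at least 1.9-fold higher number from compound 1 to compound 3 (0.29 log units; that floor lies within the scatter), so this step gives a floor and its true size is unknown. The step between compound 2 and compound 3 cannot be read, and the position on a saturated chain carbon bound to a carbonyl carbon now holds two different groups, (4-methyl-4H-1,2,4-triazol-3-yl)sulfanyl and (1H-benzimidazol-2-yl)oxy, that both end at the same limit: the limit of > 200000 nM in this assay, at which 2 of the 3 values shown sit.

From the compounds shown here alone, how far compound 2 and compound 3 lie past that limit remains open, as does whether the oxygen link or the benzimidazole counts for more in compound 3, since the two enter together. Also open, going by these compounds, is what an amine or a longer chain at this position would give in this assay, and whether any group there would give a number well under that of compound 1, the only one of the three with a number.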